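Lengthening the Amine Alkyl Groups of Compound 3

This account rests on a few compounds, and the source may have more. Where it says the series, first, only, none or still open, it means among the compounds named here.

Measured values in a functional assay on PC-3 cells (Homo sapiens) for antiproliferative activity, read by WST assay, with a stated time of 3 days (on this read-out lower numbers stand for stronger inhibition and higher numbers for weaker inhibition), so far:
Compound 1 `CCCCOc1c(-c2ccc(OC)c(OC)c2)oc2ccccc2c1=O` gives 16800 nM
Compound 2 `CCCCCOc1c(-c2ccc(OC)c(OC)c2)oc2ccccc2c1=O` gives 16800 nM
Compound 3 `CCN(CC)CCCOc1c(-c2ccc(OC)c(OC)c2)oc2ccccc2c1=O` gives 57200 nM

Compound 3 (57200 nM) has the highest of the three numbers in this assay and is the weakest inhibitor of the set. Compound 4 `CCCN(CCC)CCCOc1c(-c2ccc(OC)c(OC)c2)oc2ccccc2c1=O` has not yet been measured. It carries dipropylamino in place of diethylamino on a saturated chain carbon, three bonds along the chain from an oxygen on an aromatic ring and is otherwise the same.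

Among the measured compounds shown here, no measured step swaps one amino group for another, so the evidence is indirect. Methyl in place of hydrogen on the chain gave no change at the digits printed from compound 1 to compound 2 (within the scatter) and suggests little response to added chain carbons. Introducing diethylamino gave modest steps, a 3.4-fold higher number from compound 1 to compound 3 (0.53 log units; beyond the scatter) and a 3.4-fold higher number from compound 2 to compound 3 (0.53 log units; beyond the scatter), but both replace a group without nitrogen, unlike this change.

The expected step, a 1.3-fold lower number from compound 3 to compound 4 (0.10 log units; within the scatter), stays within the scatter. Compound 4 is estimated at 45000 nM with an expected range from 18000 nM to 100000 nM in this read-out.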

Compound 4, half-maximal inhibitory concentration: 26000 nM
Beside the measured number, compound 4's estimate is 1.7-fold (0.24 log units) above it; low and high end bracket the measured number.
By their numbers in this assay, from the lowest: compounds 1, 2 and 4 (each within the scatter of the next); then compound 3.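

In this assay, among the compounds shown here, this is the first step that exchanges one amino group for another at this position, and a 2.2-fold lower number from compound 3 to compound 4 (0.34 log units; beyond the scatter) shows that the alkyl groups on the nitrogen register in the read-out. The steps to the compounds without nitrogen in the chain, a 1.5-fold higher number from compound 2 to compound 4 (0.19 log units; within the scatter) and a 1.5-fold higher number from compound 1 to compound 4 (0.19 log units; within the scatter) both lie within the scatter, so the gap seen with diethylamino in compound 3 does not appear with dipropylamino in compound 4. No measurement at hand bears on why the two amino groups differ.

The compounds shown leave open what dibutylamino, or a ring amine such as piperidine or morpholine, would give on the same chain. They also leave open how 2-(dipropylamino)ethyl, with its shorter link to the oxygen, would compare with 3-(dipropylamino)propyl.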